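The source may hold more compounds than are shown below. What is called first, only, known or untested is meant among the compounds shown, and "the series" means these compounds.

Compound 1 `CC1(C)C=C(n2ccccc2=O)c2cc(C(=O)c3ccccc3)ccc2O1`: 6.61 in a functional assay (aorta) with Rattus norvegicus as the target; a higher number here means a more potent compound, by a factor of ten per unit of this negative logarithm, a lower number a less potent compound
Compound 2 `CC1(C)C=C(n2ccccc2=O)c2cc(O)ccc2O1`: 5.44
Compound 3 `CC1(C)C=C(n2ccccc2=O)c2cc(OC(=O)Nc3ccccc3)ccc2O1`: 5.3

Compound 1 stands highest of the three numbers in this assay; compound 2 is nearest and compound 3 furthest, both beyond the scatter. The unmeasured compound 4 `CC1(C)C=C(n2ccccc2=O)c2cc(C(F)(F)F)ccc2O1` differs from compound 1 in one place: trifluoromethyl in place of benzoyl on an aromatic carbon. The step that bears on this is a number 1.17 log units lower from compound 1 to compound 2 (beyond the scatter), where the benzoyl likewise leaves and a small group enters. The step of a number 0.14 log units lower from compound 2 to compound 3 (within the scatter) concerns a different group and says little here. Because a number 1.17 log units lower from compound 1 to compound 2 (beyond the scatter) shows a large loss when the benzoyl is removed, a drop is expected for compound 4 as well, though a trifluoromethyl is not a hydroxy and the size is uncertain. Compound 4 is therefore expected to show a number 0.71 log units lower from compound 1 to compound 4 (beyond the scatter). The estimated value of compound 4 is 5.9, with a range from 5.2 to 6.6.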

Compound 4, logarithm of the reciprocal of the active concentration, log(1/C): 7.61
Compound 4: middle estimate off by 1.71 log units, on the low side; measured number outside the range, above it.
By their numbers in this assay, from the lowest: compounds 3 and 2 (each within the scatter of the next); then compound 1; then compound 4.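

In this assay, the benzoyl on this aromatic carbon can be replaced with a gain, as trifluoromethyl, which has no ring, gives a higher number (a number 1.00 log units higher from compound 1 to compound 4 (beyond the scatter)). The loss seen with hydroxy therefore does not extend to every group with fewer heavy atoms than benzoyl: trifluoromethyl stands far above hydroxy (a number 2.17 log units higher from compound 2 to compound 4 (beyond the scatter)). Nothing given here explains the difference between these groups. Going by these compounds, whether a nitrile or an amine on this carbon would match trifluoromethyl remains open. So does whether a methyl, which has no fluorine, would keep the gain.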